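The source may hold more compounds than are shown below. What is called first, only, known or untested is meant among the compounds shown, and "the series" means these compounds.

Measured so far in an ADME assay on HaCaT cells (Homo sapiens) for antiproliferative activity, with a stated time of 48 h; a lower number here means a stronger inhibitor, a higher number a weaker inhibitor:
compound 1 `CCN(CC)c1ccc(-c2cccc(C#N)c2)nn1` — for compound 1 only a limit of the assay is reported, > 25000 nM.
compound 2 `CCN(CC)c1ccc(-c2ccc(C#N)cc2)nn1` — for compound 2 the value is likewise a limit, > 25000 nM.
compound 3 `CCOC(=O)c1ccc(-c2ccc(N(CC)CC)nn2)cc1` — compound 3 gives 500 nM.

For the measured compounds named here, the one measured step is an at least 50-fold lower number from compound 2 to compound 3 (1.69 log units; beyond the scatter); the change is ethoxycarbonyl in place of cyano on an aromatic carbon. How the cores of compound 1 and compound 2 differ is not broken down here. Compound 4 `CCOC(=O)c1cccc(-c2ccc(N(CC)CC)nn2)c1` carries the same kind of change relative to compound 1, (ethoxycarbonyl in place of cyano on an aromatic carbon), but its place line reads meta to a large group where the measured step reads para to a large group. Note (the limit of > 25000 nM in this assay, at which 2 of the 3 values shown sit), so the size of the measured step is itself a lower bound. For compound 4 the step of an at least 12-fold lower number from compound 1 to compound 4 (1.09 log units; beyond the scatter) is expected, set beside an at least 50-fold lower number from compound 2 to compound 3 (1.69 log units; beyond the scatter) and resting on the limit for compound 1 in this assay, > 25000 nM, and on the fact that the change in this assay has only been seen once. The estimate for compound 4 is 2000 nM, between 400 nM and 15000 nM.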

Compound 4, half-maximal inhibitory concentration: > 25000 nM
Compound 4 ended at the assay's limit; the forecaster's own chance of this, stated with the estimate: 25%; middle value at least 12-fold (1.09 log units) from the limit.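

In this assay compound 4 gives > 25000 nM, which is a limit of the assay. No step can be read from compound 1 to compound 4, since both stand at a limit: the limit of > 25000 nM in this assay, at which 3 of the 4 values shown sit.

The compounds shown leave open whether ethoxycarbonyl in place of cyano changes the number at all when meta to a large group.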